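A few compounds are considered here, and "the series" means these few. Any claim that something is new, unique, unknown or untested is made for them only; others in the source may bear on it.

Measured compounds:
Compound 1 `CC1CCN(c2c(S(=O)(=O)c3ccc(Cl)c(Cl)c3)cnc3ccc(Cl)cc23)CC1`: 55.6 nM
Compound 2 `CC1CCN(c2c(S(=O)(=O)c3cccc(F)c3)cnc3cc(Cl)ccc23)CC1`: "not determined" (no result reported)
Compound 3 `O=S(=O)(c1ccccc1)c1cnc2ccccc2c1N1CCCCCC1`: 310 nM

In an assay on isolated protein for displacement of a labelled ligand from metabotropic glutamate receptor 5 (Homo sapiens), with a stated time of 60 min (on this read-out lower numbers stand for stronger inhibition and higher numbers for weaker inhibition), compound 1 gives 55.6 nM and compound 3 gives 310 nM. The two differ in several places at once, so their gap is taken only for what the two values show. Compound 2 has no number in this assay: the result was not determined, so it stands nowhere on the scale that compounds 1 and 3 define, and any sense of where it lies rests on how much of its structure it shares with compound 1.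

Compound 4, `CC1CCN(c2c(S(=O)(=O)c3cc(F)cc(F)c3)cnc3cc(Cl)ccc23)CC1`, differs from compound 2 in one place: fluoro in place of hydrogen on an aromatic carbon. Among the compounds with values here, no measured pair shows this change, so its size cannot be read from the data. The account expects a step in this assay no larger than the usual scatter, with the direction left open. Because compound 1 gives 55.6 nM with a closely related structure, compound 4 is estimated at 80 nM, with a range from 20 nM to 400 nM.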

Compound 4, inhibition constant: 195 nM
For compound 4 the middle estimate is 2.4-fold (0.39 log units) below the measured one; low and high end bracket the measured number.
By their numbers in this assay, from the lowest: compound 1; then compounds 4 and 3 (each within the scatter of the next).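

Of compound 2 and compound 4, only compound 4 carries a number in this assay, and no step can be read between them. The compounds shown leave open whether going from 3-fluorophenyl to 3,5-difluorophenyl shifts the value at all, and in which direction. Nothing shown here offers an explanation for the value of compound 4.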